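Arylamino in place of alkylamino on the shared core

The source may report more compounds than this note shows. Statements on the series, on what has been measured and on what is new or still open speak of the compounds shown alone.

Three amides have numbers in an in vitro assay on HEK-tsA201 cells for antagonist activity at Neuronal acetylcholine receptor; alpha4/beta2 (Homo sapiens), read by fluorescence and calcium flux; on this read-out higher numbers stand for weaker inhibition and lower numbers for stronger inhibition. Compound 1 `C#CCOc1ccc(C(=O)Nc2cccc(C)n2)cc1` gives 19400 nM in this assay, compound 2 `CCCOc1ccc(C(=O)Nc2cnccn2)cc1` gives 23200 nM, and compound 3 `CCCNc1cccc(NC(=O)c2ccc(OCCC)cc2)n1` gives 15400 nM. Compound 3 has the lowest of the three numbers, but its gaps to compound 1 and to compound 2 both fall within the scatter, so no order among them can be read.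

Compound 4 `CCCOc1ccc(C(=O)Nc2cccc(Nc3cccc(F)c3)n2)cc1` differs from compound 3 in one place: 3-fluorophenyl in place of propyl on a nitrogen on an aromatic ring. The propylamino group becomes a (3-fluorophenyl)amino group; the amide and the propoxy side are unchanged. For the measured compounds named here, no measured pair here shows what such an exchange does, so the expected step from compound 3 to compound 4 in this assay is estimated as a 1.3-fold lower number from compound 3 to compound 4 (0.11 log units; within the scatter), a small movement that may not exceed the scatter, with a lean toward a lower number. Compound 4 is therefore expected to give about 12000 nM in this assay, within a range from 4000 nM to 35000 nM.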

Compound 4, half-maximal inhibitory concentration: > 100000 nM
Compound 4: only a limit was reported; the forecaster's own chance of this, stated with the estimate: 10%; middle value at least 8.3-fold (0.92 log units) from the limit.
By their numbers in this assay, from the lowest: compounds 3, 1 and 2 (each within the scatter of the next). At a limit, above all of these: compound 4.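

Compound 4 gives only a limit in this assay, > 100000 nM. Replacing propyl with 3-fluorophenyl on a nitrogen on an aromatic ring gives an at least 6.4-fold higher number from compound 3 to compound 4 (0.81 log units; beyond the scatter), so the group at this position can shift the read-out, which the three earlier amides, all within the scatter of one another, could not show. Only a minimum for this step can be read, and it rests on a single pair: the limit of > 100000 nM in this assay, at which 1 of the 4 values shown sits.

From the compounds shown here alone, it remains open whether the higher number goes with the aromatic ring or with the fluorine; a plain phenyl group on the same nitrogen would separate the two. A benzyl group, a longer alkyl chain such as butyl, or an unsubstituted amino group at this position would show how far the propylamino result extends.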